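The source may hold more compounds than are shown below. What is called first, only, known or untested is meant among the compounds shown, and "the series" means these compounds.

Measured so far in a physicochemical assay for acid dissociation:
- compound 1 `CN(Cc1ccc(N(C)C)cc1)Cc1cccc(CNc2ccnc3cc(Cl)ccc23)c1` gives 9.67 
- compound 2 `CN(Cc1ccc(Cl)cc1)Cc1cccc(CNc2ccnc3cc(Cl)ccc23)c1` gives 9.89 

Compound 2 at 9.89 lies within the scatter of compound 1 at 9.67 and so the two cannot be separated on these numbers. The next compound is compound 3 `COc1ccc(CN(C)Cc2cccc(CNc3ccnc4cc(Cl)ccc34)c2)cc1`, which differs from compound 2 by methoxy in place of chloro on an aromatic carbon, para to a large group (methoxy in place of chloro on an aromatic carbon).

Among the measured compounds shown here, no measured compound carries methoxy, so the evidence is indirect. For the measured compounds named here, only one measured step bears on this change: a number 0.22 log units higher from compound 1 to compound 2 (within the scatter), with chloro in place of dimethylamino on an aromatic carbon. On that single step, no change beyond the scatter is expected in this assay, and two compounds give no basis for a direction. The estimated step is a number 0.09 log units lower from compound 2 to compound 3 (within the scatter) and is expected to stay within the scatter. For compound 3 the expected value is 9.8 within an estimated range of 9.45 to 10.1.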

Compound 3, acid dissociation constant: 9.67
For compound 3 the middle estimate is 0.13 log units above the measured one; the measured number falls inside the stated range.
By their numbers in this assay, from the lowest: compounds 1, 3 and 2 (each within the scatter of the next).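

In this assay, the aromatic carbon para to a large group now carries a third group, methoxy, and methoxy in place of chloro gives a number 0.22 log units lower from compound 2 to compound 3 (within the scatter), so this change separates the two compounds no more than the earlier chloro for dimethylamino step did. Methoxy in place of dimethylamino gives no change at the digits printed from compound 1 to compound 3 (within the scatter), which closes the remaining comparison: across the three compounds shown, with dimethylamino, chloro and methoxy at this position, every pair lies within the scatter, and none of these groups can be ranked against another on these numbers. No measurement is available that would account for these readings.

Open, on these data alone, is whether a group of a different kind at this position, such as a carboxylic acid, a primary amine or a longer alkoxy chain, would give a step beyond the scatter. Also open, as far as these compounds go, is whether any change outside this position, such as a plain benzyl or a non-aromatic group in place of the whole 4-methoxybenzyl, would give a number that can be separated from these three.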